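Hydroxyphenyl to Chlorophenyl: an Expected Drop in Cytotoxicity

The source may report more compounds than this note shows. Statements on the series, on what has been measured and on what is new or still open speak of the compounds shown alone.

Of the compounds shown here, three sharing one core have been tested in an ADME assay on Vero cells (Chlorocebus sabaeus) for cytotoxicity, read by neutral red uptake, tested at 787 ug/mL; a higher number here means a weaker effect of the compound at the concentration tested, a lower number a stronger effect. Compound 2 `O=C1CSC(c2cccc(O)c2)N1CCN1CCCCC1` gives 60%, the highest of the three numbers. Compound 3 `COc1cccc(C2SCC(=O)N2CCN2CCCCC2)c1` gives 19%, and compound 1 `O=C1CSC(c2c(Cl)cccc2Cl)N1CCN1CCCCC1`, whose aromatic ring carries chlorine and no hydroxyl, gives 11%. Going by the values given here, the only single-point step among them is a number 41 percentage points lower from compound 2 to compound 3 (beyond the scatter), a large drop that goes with a methyl in place of hydrogen on an oxygen on an aromatic ring.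

Compound 4 `O=C1CSC(c2ccc(Cl)cc2)N1CCN1CCCCC1` has not yet been measured. It differs from compound 2 in one place: 4-chlorophenyl in place of 3-hydroxyphenyl on a saturated ring carbon. This change too does away with the hydroxyl, and it brings chlorine onto the ring. Because a number 41 percentage points lower from compound 2 to compound 3 (beyond the scatter) was large and downward, and because compound 1 at 11% stands far below compound 2, a large downward step is expected in this assay, about a number 40 percentage points lower from compound 2 to compound 4 (beyond the scatter). Compound 4 is therefore estimated at 20%, with a range from 8% to 40%.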

Compound 4, a percentage reported as activity, at one concentration (the size of the read-out at that concentration, not a potency): 15%
Beside the measured number, compound 4's estimate is 5 percentage points above it; the measured number falls inside the stated range.
By their numbers in this assay, from the lowest: compounds 1, 4 and 3 (each within the scatter of the next); then compound 2.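

In this assay the change to 4-chlorophenyl gives a number 45 percentage points lower from compound 2 to compound 4 (beyond the scatter), so a second change at this saturated ring carbon, one that removes the hydroxyl entirely instead of placing a methyl on its oxygen, also comes with a large fall. Of the four compounds, compound 2 alone keeps a hydroxyl on its aromatic ring and alone stands apart at the top, and no compound shown goes against this pairing. Nothing measured here explains the link.

This single swap loses the hydroxyl, brings in chlorine and shifts the substituent's ring position all at once, so 4-hydroxyphenyl and 3-chlorophenyl would be needed to pull these apart. As far as these compounds go, how an amine or a carboxylic acid on the aromatic ring would read at this place also stays open.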